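The source may hold more compounds than are shown below. What is called first, only, known or untested is meant among the compounds shown, and "the series" means these compounds.

Compound 1 `CSc1ccc(F)cc1NCC1=NCCN1`: 2.29 nM
Compound 2 `COc1ccc(SC)c(NCC2=NCCN2)c1`: 1.59 nM
Compound 3 `CSc1ccc(Cl)cc1NCC1=NCCN1`: 0.437 nM

In a functional assay for agonist activity at Alpha-1A adrenergic receptor (Homo sapiens) (on this read-out higher numbers stand for an effect only at larger amounts of compound and lower numbers for an effect already at smaller amounts), compound 3 stands lowest of the three numbers, and since both steps leading to it lie beyond the scatter it is the most potent of the measured set. Those steps are a 5.2-fold lower number from compound 1 to compound 3 (0.72 log units; beyond the scatter) and a 3.6-fold lower number from compound 2 to compound 3 (0.56 log units; beyond the scatter); by contrast a 1.4-fold lower number from compound 1 to compound 2 (0.16 log units; within the scatter) stays within the scatter. Compound 4 `CSc1ccc(C(F)(F)F)cc1NCC1=NCCN1` differs from compound 3 in one place: trifluoromethyl in place of chloro on an aromatic carbon. Within the data shown here, no measured step exchanges chloro for trifluoromethyl, so the two steps ending at compound 3 are the only ones that bear on this position; they show that what sits there can move this assay by a modest amount, and that chloro has given the lowest number so far. Among the measured compounds shown here, with no direct precedent, the step from compound 3 to compound 4 is expected to be small, most likely a slight rise in the number, a 2.1-fold higher number from compound 3 to compound 4 (0.31 log units; beyond the scatter). For compound 4 the expected value in this assay is 0.9 nM, with a range from 0.25 nM to 3.5 nM.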

Compound 4, half-maximal effective concentration: 10.5 nM
Beside the measured number, compound 4's estimate is 12-fold (1.07 log units) below it, and the stated range ends below it.
By their numbers in this assay, from the lowest: compound 3; then compounds 2 and 1 (each within the scatter of the next); then compound 4.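

Trifluoromethyl on this aromatic carbon, para to a methylsulfanyl group, shows that the position can move this assay much further than the earlier exchanges among fluoro, methoxy and chloro did: the change gives a 24-fold higher number from compound 3 to compound 4 (1.38 log units; beyond the scatter). The number also rises against the other two groups, with a 6.6-fold higher number from compound 2 to compound 4 (0.82 log units; beyond the scatter) and a 4.6-fold higher number from compound 1 to compound 4 (0.66 log units; beyond the scatter), so this position does not accept every substituent equally, and compound 4 is the least potent of the four. Nothing available explains why this exchange has so large an effect.

The compounds shown leave open whether the rise is particular to trifluoromethyl or would recur with other groups at this carbon, such as bromo, a nitrile or an amine. They also leave open whether the same exchange would have a comparable effect elsewhere on the shared core.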